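From nitro to fluoro: compound 2 and compound 4

The source may hold more compounds than are shown below. What is called first, only, known or untested is meant among the compounds shown, and "the series" means these compounds.

Compound 1 (`COc1cc(OC)c2sc(-c3ccc(N/C=C\C(=O)c4ccc(OC)c([N+](=O)[O-])c4)c(C)c3)nc2c1`): 9390 nM
Compound 2 (`COc1cc(OC)c2sc(-c3ccc(N/C=C\C(=O)c4ccc(OC)c([N+](=O)[O-])c4)cc3)nc2c1`): 12900 nM
Compound 3 (`COc1ccc(C(=O)/C=C\Nc2ccc(-c3nc4cc(OC)c(OC)c(OC)c4s3)cc2)cc1[N+](=O)[O-]`): 11400 nM
Compound 4 (`COc1cc(OC)c2sc(-c3ccc(N/C=C\C(=O)c4ccc(OC)c(F)c4)cc3)nc2c1`): not yet measured

In a functional assay on HeLa cells (Homo sapiens) for antiproliferative activity, read by sulforhodamine B assay, with a stated time of 48 h (on this read-out higher numbers stand for weaker inhibition and lower numbers for stronger inhibition), compound 2 gives 12900 nM and cannot be separated from the other two measured compounds. Compound 4 differs from compound 2 in one place, with fluoro in place of nitro on an aromatic carbon. Going by the values given here, the two measured steps (a 1.4-fold higher number from compound 1 to compound 2 (0.14 log units; within the scatter) and a 1.1-fold lower number from compound 2 to compound 3 (0.05 log units; within the scatter)) both stayed within the scatter, but neither touches the nitro group, and no measured compound varies it. They therefore give only a weak guide and no direction for this swap. The estimated change is a 1.3-fold lower number from compound 2 to compound 4 (0.11 log units; within the scatter) and so no expected step beyond the scatter. The estimate for compound 4 is 10000 nM with 3000 nM to 30000 nM as its expected range.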

Compound 4, half-maximal inhibitory concentration: 7300 nM
For compound 4 the middle estimate is 1.4-fold (0.14 log units) above the measured one; the range from low to high includes it.
By their numbers in this assay, from the lowest: compounds 4, 1, 3 and 2 (each within the scatter of the next).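

Going by these compounds alone, this is the first change at this position that can be read: in this assay, fluoro in place of nitro gives a 1.8-fold lower number from compound 2 to compound 4 (0.25 log units; within the scatter) on the same core. Within the data shown here, three heavy atoms on this ring can thus give way to a single fluorine with no step beyond the scatter, something the earlier compounds, which all carry nitro, could not show. Nothing measured here gives a reason for this result. Still open, from the compounds shown here alone, is whether an amine or a carboxylic acid at this position would give a step beyond the scatter. Also open, going by these compounds, is whether fluoro in place of nitro would read the same on the cores of compound 1 and compound 3.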